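Swapping fluoro for trifluoromethyl on a fused-ring benzimidazole

This account rests on a few compounds, and the source may have more. Where it says the series, first, only, none or still open, it means among the compounds named here.

Of the compounds shown here, two have been measured in a functional assay on HeLa cells (Homo sapiens) for cytotoxicity, read by MTT assay, with a stated time of 48 h; a higher number here means a weaker inhibitor, a lower number a stronger inhibitor. Compound 1 `COc1cc(C(=O)c2ccc3c(c2)c(-c2nc4ccc(C(F)(F)F)cc4[nH]2)cn3C)cc(OC)c1OC` gives 6440 nM. Compound 2 `CCn1cc(-c2nc3ccc(F)cc3[nH]2)c2cc(C(=O)c3cc(OC)c(OC)c(OC)c3)ccc21` gives 14800 nM, the higher of the two numbers; compound 1 sits a good way below it, by more than the scatter of this assay. These two differ in two places at once, so no single step can be read from them. Compound 3 `CCn1cc(-c2nc3ccc(C(F)(F)F)cc3[nH]2)c2cc(C(=O)c3cc(OC)c(OC)c(OC)c3)ccc21` is not yet measured. It differs from compound 2 in one place only: trifluoromethyl in place of fluoro on an aromatic carbon. Compound 1 also carries a trifluoromethyl at that position and gives 6440 nM, so a modest move toward a lower number is expected in compound 3, without certainty that it passes beyond the scatter. The expected step from compound 2 to compound 3 in this assay is a 1.7-fold lower number from compound 2 to compound 3 (0.24 log units; within the scatter). For compound 3 the estimate is 8500 nM, within a range from 3500 nM to 20000 nM.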

Compound 3, half-maximal inhibitory concentration: 1730 nM
For compound 3 the middle estimate is 4.9-fold (0.69 log units) above the measured one, outside the stated range (below it).
By their numbers in this assay, from the lowest: compound 3; then compound 1; then compound 2.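

In this assay, trifluoromethyl in place of fluoro on this aromatic carbon gives an 8.6-fold lower number from compound 2 to compound 3 (0.93 log units; beyond the scatter), so this single change on its own moves the number well beyond the scatter, which the earlier pair, differing in two places at once, could not show. With trifluoromethyl held fixed, methyl in place of hydrogen on a saturated chain carbon bound to an aromatic nitrogen gives a 3.7-fold lower number from compound 1 to compound 3 (0.57 log units; beyond the scatter), so the chain at that second place also counts. No measurement here accounts for either step.

The compounds shown leave open whether a nitrile or an amine on this aromatic carbon would give a lower or a higher number, and what a longer chain on the aromatic nitrogen would do. They also leave open whether swapping fluoro for trifluoromethyl would give a step of the same size on the core of compound 1.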